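Longer acyl chains and a cytidine-like core: extending further

The source may hold more compounds than are shown below. What is called first, only, known or untested is meant among the compounds shown, and "the series" means these compounds.

Measured compounds:
compound 1 `CCCCCCCCCCCC(=O)Nc1ccn([C@@H]2CO[C@H](CO)O2)c(=O)n1`: 30 nM
compound 2 `CCCCCCCCCCCCCCCC(=O)Nc1ccn([C@@H]2CO[C@H](CO)O2)c(=O)n1`: 20 nM
compound 3 `CCCCCCCCCCCCCCCCCCCC(=O)Nc1ccn([C@@H]2CO[C@H](CO)O2)c(=O)n1`: 150 nM

In a functional assay on SW1573 cells (Homo sapiens) for cytotoxicity, read by sulforhodamine B assay, with a stated time of 72 h (on this read-out higher numbers stand for weaker inhibition and lower numbers for stronger inhibition), compound 3 gives the highest number of the three, with a 5.0-fold higher number from compound 1 to compound 3 (0.70 log units; beyond the scatter) and a 7.5-fold higher number from compound 2 to compound 3 (0.88 log units; beyond the scatter), while a 1.5-fold lower number from compound 1 to compound 2 (0.18 log units; within the scatter). Compound 4 `CCCCCCCCCCCCCCCCCCCCCC(=O)Nc1ccn([C@@H]2CO[C@H](CO)O2)c(=O)n1` differs from compound 3 only by ethyl in place of hydrogen on a saturated chain carbon, ten or more bonds along the chain from a carbonyl carbon. The two steps that lengthen the chain toward compound 3 both raised the number beyond the scatter, though the shorter extension from compound 1 to compound 2 did not. Continuing the chain is therefore expected to raise the number again in this assay, by a modest step. Compound 4 is estimated at 350 nM, with a range of 150 nM to 800 nM. The expected step is a 2.3-fold higher number from compound 3 to compound 4 (0.37 log units; beyond the scatter).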

Compound 4, half-maximal inhibitory concentration: 900 nM
Estimate against measurement, compound 4: 2.6-fold (0.41 log units) below; measured number above the stated range.
By their numbers in this assay, from the lowest: compounds 2 and 1 (each within the scatter of the next); then compound 3; then compound 4.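

In this assay the rise seen at compound 3 continues with ethyl in place of hydrogen on the chain, giving a 6.0-fold higher number from compound 3 to compound 4 (0.78 log units; beyond the scatter) and making compound 4 the weakest of the four. Measured against the two shortest chains, the hexyl change gives a 45-fold higher number from compound 2 to compound 4 (1.65 log units; beyond the scatter) and the decyl change gives a 30-fold higher number from compound 1 to compound 4 (1.48 log units; beyond the scatter) as large steps, so the effect of chain length at this far end of the chain is steep rather than levelling off. Nothing measured here explains this climb in the numbers.

Still open, as far as these compounds go, is whether a longer chain would keep raising the number, and whether a chain carrying a carboxylic acid or an amine would follow the same trend.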